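Changing the ring on the carbamoyl nitrogen

The source may report more compounds than this note shows. Statements on the series, on what has been measured and on what is new or still open speak of the compounds shown alone.

Compound 2 `CC(C)=CCC/C(C)=C/CC1Cc2c(OC(=O)Nc3ccccc3F)cc(=O)n(CCCO)c2CC1(C)C` gives 71.6% in a functional assay on PANC-1 cells (Homo sapiens) for inhibition, read by MTT assay, with a stated time of 24 h, tested at 10 uM; a lower number here means less inhibition, a higher number more inhibition at the concentration tested (going by the name of the read-out). It stands at the low end of the two numbers shown, yet compound 1 `CC(C)=CCC/C(C)=C/CC1Cc2c(OCCCNC(=O)c3cccs3)cc(=O)n(CCCO)c2CC1(C)C`, which gives 72.8%, lies within the scatter of it, the gap being a number 1.2 percentage points lower from compound 1 to compound 2 (within the scatter). Compound 3 `CC(C)=CCC/C(C)=C/CC1Cc2c(OC(=O)Nc3ccc(Cl)c(Cl)c3)cc(=O)n(CCCO)c2CC1(C)C` differs from compound 2 in one place: 3,4-dichlorophenyl in place of 2-fluorophenyl on an amide-type nitrogen. Within the data shown here, the single measured step alters a different part of the shared core, so no step bears directly on this change, and that step was itself small. Compound 3 is therefore expected to move by about a number 0.4 percentage points higher from compound 2 to compound 3 (within the scatter), nothing beyond the scatter, with an estimated 72% in this assay, between 60% and 84%.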

Compound 3, a percentage reported as inhibition, at one concentration (the size of the read-out at that concentration, not a potency): 20%
Estimate against measurement, compound 3: 52 percentage points above; the measured number lies below the stated range.
By their numbers in this assay, from the lowest: compound 3; then compounds 2 and 1 (each within the scatter of the next).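

On the amide-type nitrogen, replacing 2-fluorophenyl with 3,4-dichlorophenyl gives a number 51.6 percentage points lower from compound 2 to compound 3 (beyond the scatter) in this assay, so the outcome depends strongly on this ring. The earlier pair, with very different groups on the oxygen, showed no such sensitivity, whereas (3,4-dichlorophenyl)carbamoyl on that oxygen gives a number 52.8 percentage points lower from compound 1 to compound 3 (beyond the scatter). Nothing available explains this loss of inhibition.

From the compounds shown here alone, whether the step comes from gaining the two chlorines, from their places on the ring, or from losing the fluorine remains open. An unsubstituted phenyl or a cyclohexyl on that nitrogen could help separate these possibilities.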